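The compounds below may be only part of what the source reports. "The series", "measured", "known", "first", "only" and "open" are said of these compounds alone.

Three compounds share one core and differ only in the group on the sulfonyl sulfur. Compound 1 `O=C(NCc1ccc(CNS(=O)(=O)c2ccc(Cl)cc2)cc1)c1ccc(CNc2ncccn2)cc1` carries a 4-chlorophenyl there; in an assay on MDA-MB-231 cells for binding affinity to C-X-C chemokine receptor type 4 (Homo sapiens), read by microscopy, with stated times of 10 min and 30 min (on this read-out lower numbers stand for an effect already at smaller amounts and higher numbers for an effect only at larger amounts of compound), compound 1 gives 100 nM. Compound 2 `O=C(NCc1ccc(CNS(=O)(=O)c2cccc(Cl)c2)cc1)c1ccc(CNc2ncccn2)cc1` carries a 3-chlorophenyl; in this assay compound 2 gives 1 nM, so a 100-fold lower number from compound 1 to compound 2 (2.00 log units; beyond the scatter). Compound 3 `O=C(NCc1ccc(CNS(=O)(=O)c2ccc(F)c(F)c2)cc1)c1ccc(CNc2ncccn2)cc1` carries a 3,4-difluorophenyl; in this assay compound 3 gives 100 nM. Compound 3 stands level with compound 1, the two together at the top of the three numbers, with no change at the digits printed from compound 1 to compound 3 (within the scatter), while a 100-fold higher number from compound 2 to compound 3 (2.00 log units; beyond the scatter).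

Compound 4 `O=C(NCc1ccc(CNS(=O)(=O)c2ccccc2)cc1)c1ccc(CNc2ncccn2)cc1` follows from compound 3 by one change: phenyl in place of 3,4-difluorophenyl on a sulfonyl sulfur. Going by the values given here, no measured step strips both ring substituents away. Among the compounds with values here, the steps that bear on this position are a 100-fold lower number from compound 1 to compound 2 (2.00 log units; beyond the scatter) and a 100-fold higher number from compound 2 to compound 3 (2.00 log units; beyond the scatter), both large, so the number is sensitive to where the ring is substituted. A bare phenyl matches neither measured pattern, so a step in either direction beyond the scatter remains possible; the working expectation is no change beyond the scatter from compound 3, no change at the digits printed from compound 3 to compound 4 (within the scatter). For compound 4 in this assay the estimate is 100 nM, within a range from 15 nM to 700 nM.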

Compound 4, effective concentration (reported as EC, without a stated level of effect): 1 nM
Compound 4: middle estimate off by 100-fold (2.00 log units), on the high side; measured number outside the range, below it.
By their numbers in this assay, from the lowest: compounds 2 and 4 (each within the scatter of the next); then compounds 1 and 3 (each within the scatter of the next).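

In this assay the bare phenyl groups with the 3-chlorophenyl and not with the other two rings: no change at the digits printed from compound 2 to compound 4 (within the scatter), against a 100-fold lower number from compound 1 to compound 4 (2.00 log units; beyond the scatter) and a 100-fold lower number from compound 3 to compound 4 (2.00 log units; beyond the scatter). The low number therefore needs no ring substituent, and among these compounds the 3-chlorophenyl adds nothing measurable over phenyl, while the 4-chlorophenyl and the 3,4-difluorophenyl are the two rings that share the higher number. No measurement at hand accounts for this difference.

Open, on these data alone, is whether a single fluoro on the phenyl follows the chloro pattern, and whether a 4-methylphenyl or 4-methoxyphenyl also shares the higher number. Also open, as far as these compounds go, is whether the sulfonyl sulfur tolerates something other than a benzene ring, such as a pyridine or a short alkyl chain.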